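Thiophene Replaces Cyclobutyl on the Carbonyl Carbon

A few compounds are considered here, and "the series" means these few. Any claim that something is new, unique, unknown or untested is made for them only; others in the source may bear on it.

Compound 2 `COc1cc2c(c(O)c1C(=O)/C=C/c1ccc(OC(=O)C3CCC3)cc1)CCC(C)(C)O2` was tested in an assay on HEK293T cells for inhibition of nuclear factor NF-kappa-B complex (Homo sapiens), read by a luciferase reporter; a lower number here means a stronger inhibitor, a higher number a weaker inhibitor. In this assay compound 2 gives only the limit > 30000 nM, so no number is known for it. Compound 1 `COc1cc2c(c(O)c1C(=O)/C=C/c1ccc(OC(=O)c3cccc(Cl)c3)cc1)CCC(C)(C)O2` likewise stops at the limit > 30000 nM. The step that the two limits leave unreadable from compound 1 to compound 2 is therefore unreadable, and both values sit at the limit of > 30000 nM in this assay, at which 2 of the 2 values shown sit. Compound 3 `COc1cc2c(c(O)c1C(=O)/C=C/c1ccc(OC(=O)c3cccs3)cc1)CCC(C)(C)O2` carries thiophen-2-yl in place of cyclobutyl on a carbonyl carbon. Among the measured compounds shown here, with the single measured step unreadable, no direction beyond the scatter can be expected. Compound 3 is estimated at 40000 nM, in the range 15000 nM to 100000 nM, most likely again reported only as a limit. The step this estimate implies is expected to be a step that the limit leaves unreadable from compound 2 to compound 3.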

Compound 3, half-maximal inhibitory concentration: > 30000 nM
Compound 3: a limit, no number; the forecaster's own chance of this, stated with the estimate: 85%; the middle value lies beyond the limit too.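

Compound 3 gives only a limit, like compound 1 and compound 2, so no step among these compounds can be read: the limit of > 30000 nM in this assay, at which 3 of the 3 values shown sit.

The compounds shown leave open whether 3-chlorophenyl, cyclobutyl and thiophen-2-yl on the carbonyl carbon differ at all in inhibition.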